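Phenyl in place of 1H-pyrrol-1-yl: working notes

The compounds below may be only part of what the source reports. "The series", "measured", "known", "first", "only" and "open" are said of these compounds alone.

compound 1 `CC(C)c1ccc(-c2c[nH]cc2C(c2ccc(Cl)cc2Cl)n2ccnc2)cc1` gives 12700 nM
compound 2 `Clc1ccc(C(c2c[nH]cc2-c2ccc(Cl)cc2-n2cccc2)n2ccnc2)c(Cl)c1` gives 7670 nM

Both values come from an ADME assay on L6 cells (Rattus norvegicus) for cytotoxicity, read by fluorescence and resazurin assay, with a stated time of 72 h (a lower number here means that less compound is tolerated, a higher number that more compound is tolerated), and lie within the usual scatter of each other, so compound 2 holds no place apart from compound 1 on these numbers. The next compound to be measured is compound 3 `Clc1ccc(C(c2c[nH]cc2-c2ccc(Cl)cc2-c2ccccc2)n2ccnc2)c(Cl)c1` which differs from compound 2 in one place, with the change phenyl in place of 1H-pyrrol-1-yl on an aromatic carbon as counted.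

Among the compounds with values here, no measured pair in this set differs in one place, so no direct step guides the size of this change. Within the data shown here, the only guide is that compound 1 at 12700 nM and compound 2 at 7670 nM sit within the scatter of each other, and this is thin evidence. In this assay the expected 1.1-fold lower number from compound 2 to compound 3 (0.04 log units; within the scatter) stays within the usual scatter, with no direction expected beyond it. In this assay compound 3 is estimated at 7000 nM with an expected range from 3000 nM to 16000 nM for the coming measurement.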

Compound 3, half-maximal cytotoxic concentration: 14300 nM
Estimate against measurement, compound 3: 2.0-fold (0.31 log units) below; the range from low to high includes it.
By their numbers in this assay, from the lowest: compounds 2, 1 and 3 (each within the scatter of the next).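

This gives the series its first direct step: in this assay, phenyl in place of 1H-pyrrol-1-yl on an aromatic carbon gives a 1.9-fold higher number from compound 2 to compound 3 (0.27 log units; within the scatter). At this place, ortho to a large group and meta to a chloro group, the numbers therefore do not separate a five-membered aromatic ring with 1 hetero atom from a six-membered aromatic ring of carbon only, even though the hydrogen-bond acceptor counted on the leaving group is absent from the entering one. No measurement shown here accounts for this result, and the reading rests on a single pair.

The compounds shown leave open whether a group of another kind on this aromatic carbon, such as an amine, a carboxylic acid or a longer chain, would also stay within the scatter in this assay or would move the number beyond it. One step also cannot show whether the same replacement would read alike with other groups elsewhere on the shared core.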